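This account rests on a few compounds, and the source may have more. Where it says the series, first, only, none or still open, it means among the compounds named here.

Three measured compounds share one core and differ at the amine nitrogen. Compound 1 `CCc1ccc2[nH]c(=O)c(CN(Cc3ccc(O)cc3)Cc3ccc(C(C)(C)C)cc3)cc2c1` carries a 4-hydroxybenzyl there. In a toxicity assay on MDCK cells (Canis lupus familiaris) for cytotoxicity, read by crystal violet staining, with a stated time of 48 h (a lower number here means that less compound is tolerated, a higher number that more compound is tolerated), compound 1 gives only a limit, > 10000 nM. Compound 2 `CCc1ccc2[nH]c(=O)c(CN(Cc3ccc(OC(F)F)cc3)Cc3ccc(C(C)(C)C)cc3)cc2c1` carries a 4-(difluoromethoxy)benzyl instead. In this assay compound 2 likewise gives only a limit, > 5000 nM. Compound 3 `CCc1ccc2[nH]c(=O)c(CN(Cc3ccc(C(C)(C)C)cc3)C(C)c3ccc(OC)c(Cl)c3)cc2c1` carries a 1-(3-chloro-4-methoxyphenyl)ethyl. In this assay compound 3 also gives only a limit, > 10000 nM. The step that the two limits leave unreadable from compound 1 to compound 2 cannot be sized, and neither can a step that the two limits leave unreadable from compound 1 to compound 3 nor a step that the two limits leave unreadable from compound 2 to compound 3, since every value sits at a limit. Compound 3 therefore stands where the series as a whole stands: the limit of > 10000 nM in this assay, at which 2 of the 3 values shown sit, and the limit of > 5000 nM in this assay, at which 1 of the 3 values shown sits, marks the only other figure.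

Compound 4 `COc1ccc(C(C)N(Cc2ccc(C(C)(C)C)cc2)Cc2cc3cc(C4CC4)ccc3[nH]c2=O)cc1Cl` differs from compound 3 in one place: cyclopropyl in place of ethyl on an aromatic carbon. None of the three measured steps touches this position, and none of them yields a readable size, so no direction beyond the scatter is expected in this assay. Compound 4 is thus expected to remain at the limit, with a step that the limit leaves unreadable from compound 3 to compound 4 as the estimated step. The estimate for compound 4 in this assay is 15000 nM, in a range from 5000 nM to 50000 nM.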

Compound 4, half-maximal cytotoxic concentration: > 10000 nM
Compound 4 gave a limit, no number; the forecaster's own chance of this, stated with the estimate: 80%; the middle value is on the limit's open side.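

In this assay compound 3 and compound 4 both give limits rather than numbers, so no size can be read for the change from ethyl to cyclopropyl. The compounds shown leave open at what concentration any of them becomes cytotoxic to these cells, and whether any of the groups changed shifts that concentration at all.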